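Carbamate-to-amide swap at the piperidine nitrogen of series

This account rests on a few compounds, and the source may have more. Where it says the series, first, only, none or still open, it means among the compounds named here.

Measured so far in a functional assay on isolated protein for inhibition of Glucose-dependent insulinotropic receptor (Homo sapiens), read by HTRF and cAMP accumulation; a lower number here means that less compound is needed, a higher number that more compound is needed for the effect:
compound 1 `Cc1nc(S(C)(=O)=O)ccc1Oc1ncnc(OC2CCN(C(=O)OC3CCC3)CC2)c1F` gives 13.6 nM
compound 2 `Cc1nc(S(C)(=O)=O)ccc1Oc1ncnc(OC2CCN(C(=O)SC3CCC3)CC2)c1F` gives 8.51 nM

Compound 2 has the lowest of the two numbers, and the nearest is compound 1, a step of a 1.6-fold lower number from compound 1 to compound 2 (0.20 log units; within the scatter) that does not leave the scatter. Compound 3 `Cc1nc(S(C)(=O)=O)ccc1Oc1ncnc(OC2CCN(C(=O)C(C)(C)F)CC2)c1F` is not yet measured. It differs from compound 2 by 1-fluoro-1-methylethyl in place of cyclobutylsulfanyl on a carbonyl carbon on a carbonyl carbon whose other neighbours are an amide-type nitrogen in a ring. Going by the values given here, the only step that bears on this position is a 1.6-fold lower number from compound 1 to compound 2 (0.20 log units; within the scatter), where one substituent on that carbonyl was replaced by another without a change beyond the scatter. Among the compounds with values here, no measured step removes the ring or brings in a fluorine at this carbonyl, so the expectation rests on the tolerance of that single step. The step of a 1.8-fold higher number from compound 2 to compound 3 (0.25 log units; within the scatter) is therefore estimated to be small, and compound 3 is expected to give 15 nM in this assay, within 5 nM to 45 nM.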

Compound 3, half-maximal effective concentration: 76.3 nM
Compound 3: the middle estimate sits 5.1-fold (0.71 log units) below what was measured, and the stated range ends below it.
By their numbers in this assay, from the lowest: compounds 2 and 1 (each within the scatter of the next); then compound 3.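

The substituent on the carbonyl carbon is less freely exchangeable in this assay than the swap of cyclobutyloxy for cyclobutylsulfanyl alone could show: 1-fluoro-1-methylethyl in place of cyclobutylsulfanyl gives a 9.0-fold higher number from compound 2 to compound 3 (0.95 log units; beyond the scatter), and in place of cyclobutyloxy it gives a 5.6-fold higher number from compound 1 to compound 3 (0.75 log units; beyond the scatter). Both steps lie beyond the scatter, so at this carbonyl the two groups that keep the four-membered ring and the oxygen or sulfur atom are not interchangeable with the open, fluorine-bearing group. The data shown offer no measurement that explains this loss.

Going by these compounds alone, the single change removes the ring and the oxygen or sulfur atom and brings in fluorine together, so the contribution of each remains unresolved. Open too, from the compounds shown here alone, is how an amine-linked group such as cyclobutylamino, a cyclobutyl directly on the carbonyl, or an isopropyl without fluorine would read in this assay.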